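The source may hold more compounds than are shown below. What is called first, only, known or untested is meant among the compounds shown, and "the series" means these compounds.

Compound 1 `Cc1ccc(NC(=O)Nc2cc(-c3ccccc3C(=O)O)ccc2N(C)c2ccccc2C(C)(C)C)cc1` gives in an assay on HeLa cells for inhibition of Indoleamine 2,3-dioxygenase 1 (Homo sapiens), with stated times of 1 h and 18 h (on this read-out higher numbers stand for weaker inhibition and lower numbers for stronger inhibition), a reading of > 1000 nM, which is a limit of the assay rather than a number. Compound 2 `Cc1ccc(NC(=O)Nc2cc(-c3ccccc3C(=O)O)ccc2N(C)C2CCCCC2)cc1` gives 14 nM. Compound 3 `CCN(c1ccc(-c2ccccc2C(=O)O)cc1NC(=O)Nc1ccc(C)cc1)C1CCCC1` gives 23 nM.

Of the two numbers available, compound 3 has the higher one, yet its gap to compound 2, a 1.6-fold higher number from compound 2 to compound 3 (0.22 log units; within the scatter), sits within the usual scatter, so the two cannot be ranked against each other. Compound 1 stands apart at the limit of > 1000 nM in this assay, at which 1 of the 3 values shown sits.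

Compound 4 `Cc1ccc(NC(=O)Nc2cc(-c3ccccc3C(=O)O)ccc2N2CCC[C@@H]3CCCC[C@@H]32)cc1` differs from compound 3 in one place: a group of 10 heavy atoms (9 carbon, 1 nitrogen; one six-membered non-aromatic ring of carbon only, one six-membered non-aromatic ring with 1 hetero atom) in place of a group of 8 heavy atoms (7 carbon, 1 nitrogen; one five-membered non-aromatic ring of carbon only), on an aromatic carbon. Two kinds of measured step bear on this. Exchanging the 2-(tert-butyl)phenyl group on the nitrogen for a non-aromatic ring gave an at least 71-fold lower number from compound 1 to compound 2 (1.85 log units; beyond the scatter) and an at least 43-fold lower number from compound 1 to compound 3 (1.63 log units; beyond the scatter); exchanging one non-aromatic ring on the nitrogen for another gave a 1.6-fold higher number from compound 2 to compound 3 (0.22 log units; within the scatter). The group entering in compound 4 again places a non-aromatic ring on the nitrogen, so the change resembles the second kind, and a step no larger than the scatter is expected in this assay, in no particular direction. Compound 4 is therefore estimated at 30 nM, with a range from 8 nM to 120 nM. The expected step is a 1.3-fold higher number from compound 3 to compound 4 (0.12 log units; within the scatter).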

Compound 4, half-maximal inhibitory concentration: 159 nM
Beside the measured number, compound 4's estimate is 5.3-fold (0.72 log units) below it; measured number above the stated range.
By their numbers in this assay, from the lowest: compounds 2 and 3 (each within the scatter of the next); then compound 4. At a limit, above all of these: compound 1.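

The earlier pair suggested that one non-aromatic ring on this nitrogen could be swapped for another with little effect, yet the group with two six-membered non-aromatic rings reads clearly weaker in this assay, with a 6.9-fold higher number from compound 3 to compound 4 (0.84 log units; beyond the scatter) and an 11-fold higher number from compound 2 to compound 4 (1.06 log units; beyond the scatter). This group still reads stronger than the 2-(tert-butyl)phenyl group, with an at least 6.2-fold lower number from compound 1 to compound 4 (0.79 log units; beyond the scatter), so the choice of group at this position gives more than a simple split into good and poor, at least across these four compounds. That last step has only a lower bound, as the reading for compound 1 is a limit of the assay and not a number: the limit of > 1000 nM in this assay, at which 1 of the 4 values shown sits.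

In compound 4 the nitrogen lies inside a ring and the group is also larger, and the compounds shown do not separate these two changes. Also open, on these data alone, is how a piperidine on this aromatic carbon, with one ring in place of two, would read, and whether the two defined stereocentres of compound 4 matter for its number.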